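The compounds below may be only part of what the source reports. "The series", "measured", "known", "first", "only" and "open" are said of these compounds alone.

Compound 1 `CC(C)CCCN(C(=O)[C@@H]1C[C@H]1c1ccccc1)c1ccc(-c2ccccc2)cc1` was tested in a functional assay for agonist activity at G protein-coupled receptor 88 (Homo sapiens), read by HTRF and cAMP accumulation (a lower number here means that less compound is needed, a higher number that more compound is needed for the effect), and for compound 1 the assay returned only a limit, > 100 nM. For the measured compounds named here, compound 2 `CC(C)C[C@H](N)CN(C(=O)[C@@H]1C[C@H]1c1ccccc1)c1ccc(C2=CCCCCC2)cc1` gives 2100 nM in this assay, the only actual number available here. The other result recorded, that of compound 1, is a limit (the limit of > 100 nM in this assay, at which 1 of the 2 values shown sits). Compound 3 `CC(C)C[C@H](N)CN(C(=O)[C@@H]1C[C@H]1c1ccccc1)c1ccc(-c2cccc(F)c2)cc1` has not been measured; it differs from compound 2 by 3-fluorophenyl in place of cyclohept-1-en-1-yl on an aromatic carbon. Going by the values given here, no measured step compares two such compounds, so the change is expected to produce no shift beyond the scatter, a 1.4-fold lower number from compound 2 to compound 3 (0.15 log units; within the scatter). Compound 3 is therefore estimated at 1500 nM in this assay, in a range from 400 nM to 6000 nM.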

Compound 3, half-maximal effective concentration: 2100 nM
Estimate against measurement, compound 3: 1.4-fold (0.15 log units) below; the range from low to high includes it.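

At this position, on an aromatic carbon para to a large group, 3-fluorophenyl in place of cyclohept-1-en-1-yl gives no change at the digits printed from compound 2 to compound 3 (within the scatter) in this assay. A seven-membered non-aromatic carbon ring and a fluorinated six-membered aromatic ring are therefore interchangeable here, for this pair alone. Nothing recorded accounts for this outcome. Going by these compounds, it remains open whether an unsubstituted phenyl, or a fluorine elsewhere on the ring, would read the same. So does the effect of a ring carrying an amine or a carboxylic acid at this position.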